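Benzyl on the Amino Group: Extending Compound 1

This account rests on a few compounds, and the source may have more. Where it says the series, first, only, none or still open, it means among the compounds named here.

Measured so far in a functional assay on MCF7 cells (Homo sapiens) for cytotoxicity, read by MTT assay, with a stated time of 72 h; a lower number here means a stronger inhibitor of growth, a higher number a weaker inhibitor of growth:
compound 1 `CCCCC[Se]c1nc(N)c2ccccc2n1` gives 28600 nM;
compound 2 `C[Se]c1nc(N)c2ccccc2n1` gives 46500 nM;
compound 3 `[SeH]c1nc([SeH])c2cccnc2n1` gives 9830 nM.

Among these three numbers compound 1 stands second highest: its nearest neighbour is compound 2, with a 1.6-fold higher number from compound 1 to compound 2 (0.21 log units; within the scatter), while compound 3 sits furthest away with a lower number beyond the scatter. Compound 4 `CCCCC[Se]c1nc(NCc2ccccc2)c2ccccc2n1` has not been measured; it differs from compound 1 by benzyl in place of hydrogen on a nitrogen on an aromatic ring. Within the data shown here, the only measured step, that from compound 1 to compound 2, touches the chain on the selenium and not this nitrogen, so no measured step bears directly on the change. In this assay compound 4 is therefore expected to give 18000 nM, between 5000 nM and 60000 nM, which means an expected step of a 1.6-fold lower number from compound 1 to compound 4 (0.20 log units; within the scatter).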

Compound 4, concentration for 50% growth inhibition: 50 nM
Compound 4: middle estimate off by 360-fold (2.56 log units), on the high side; the whole stated range lies above it.
By their numbers in this assay, from the lowest: compound 4; then compound 3; then compounds 1 and 2 (each within the scatter of the next).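

In this assay, the nitrogen on the aromatic ring proves far more responsive than the chain on selenium: benzyl in place of hydrogen there gives a 570-fold lower number from compound 1 to compound 4 (2.76 log units; beyond the scatter), whereas the earlier step gave only a 1.6-fold higher number from compound 1 to compound 2 (0.21 log units; within the scatter). Going from amino to benzylamino is thus the one change shown here that moves the number by a large amount. Nothing available explains the size of this step.

From the compounds shown here alone, it remains open whether the aromatic ring of benzyl is needed, or whether a cyclohexylmethyl group on the same nitrogen would serve equally well. Also open, going by these compounds, is whether the chain on selenium matters once benzyl is in place.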